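The source may hold more compounds than are shown below. What is called first, only, known or untested is meant among the compounds shown, and "the series" means these compounds.

Compound 1, `O=C1NCCN1c1ccc(S(=O)(=O)Nc2cccc(Br)c2)cc1`, gives 99 nM in a functional assay on L1210 cells (Mus musculus) for antiproliferative activity, read by sulforhodamine B assay, with a stated time of 48 h; on this read-out lower numbers stand for stronger inhibition and higher numbers for weaker inhibition.
Compound 2, `COc1cccc(NS(=O)(=O)c2ccc(N3CCNC3=O)cc2)c1`, gives 240 nM.
Compound 3, `Cc1cc(C)cc(NS(=O)(=O)c2ccc(N3CCNC3=O)cc2)c1`, gives 110 nM.

Compound 1 has the lowest number of the three, with compound 3 within the scatter of it and compound 2 the only one clearly further away. Compound 4 is `Cc1ccc(C)c(NS(=O)(=O)c2ccc(N3CCNC3=O)cc2)c1` and differs from compound 1 by 2,5-dimethylphenyl in place of 3-bromophenyl on a sulfonamide nitrogen. Among the measured compounds shown here, two measured steps bear on this change. The step of a 1.1-fold higher number from compound 1 to compound 3 (0.05 log units; within the scatter), which also exchanges 3-bromophenyl for a dimethylphenyl group, stayed within the scatter, whereas a 2.4-fold higher number from compound 1 to compound 2 (0.38 log units; beyond the scatter) was a modest loss. For the measured compounds named here, no measured pair tests the 2,5-dimethylphenyl pattern itself. On the nearer precedent, compound 4 is expected to move by about a 1.3-fold higher number from compound 1 to compound 4 (0.12 log units; within the scatter). The estimate for compound 4 is therefore 130 nM, with a range from 60 nM to 300 nM.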

Compound 4, half-maximal inhibitory concentration: 81 nM
Compound 4: middle estimate off by 1.6-fold (0.21 log units), on the high side, within the range that was stated.
By their numbers in this assay, from the lowest: compounds 4, 1 and 3 (each within the scatter of the next); then compound 2.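

Placing the two methyl groups as 2,5-dimethylphenyl rather than 3,5-dimethylphenyl on the sulfonamide nitrogen makes no clear difference, with a 1.4-fold lower number from compound 3 to compound 4 (0.13 log units; within the scatter) inside the scatter, and a 1.2-fold lower number from compound 1 to compound 4 (0.09 log units; within the scatter) likewise shows that this ring need not carry bromine. Compound 4 also stands clearly apart from the methoxy compound, with a 3.0-fold lower number from compound 2 to compound 4 (0.47 log units; beyond the scatter) being a modest step. Nothing measured here accounts for these steps. The compounds shown leave open how an amine or a carboxylic acid on this ring would fare, and whether a longer chain in place of a methyl group would keep numbers in this range.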